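Extending the amide chain of a calpain-2 inhibitor

A few compounds are considered here, and "the series" means these few. Any claim that something is new, unique, unknown or untested is made for them only; others in the source may bear on it.

Three compounds share a core, compound 1 `CCOC(=O)C(=O)C(CC)NC(=O)C(CC(C)C)NC(=O)OCc1ccccc1`, compound 2 `CCCCOC(=O)C(=O)C(CC)NC(=O)C(CC(C)C)NC(=O)OCc1ccccc1` and compound 3 `CCCCCCCNC(=O)C(=O)C(CC)NC(=O)C(CC(C)C)NC(=O)OCc1ccccc1`. In an assay on isolated protein (Oryctolagus cuniculus) for inhibition of Calpain-2 catalytic subunit (Homo sapiens), at pH 8.0 (a lower number here means a stronger inhibitor, a higher number a weaker inhibitor), compound 1 gives 400 nM, and compound 2 gives 400 nM. Compound 3 gives 67 nM in this assay, the lowest of the three numbers; the two steps that lead to it are a 6.0-fold lower number from compound 1 to compound 3 (0.78 log units; beyond the scatter) and a 6.0-fold lower number from compound 2 to compound 3 (0.78 log units; beyond the scatter). Compound 4 `CCCCCCCCCCNC(=O)C(=O)C(CC)NC(=O)C(CC(C)C)NC(=O)OCc1ccccc1` differs from compound 3 by propyl in place of hydrogen on a saturated chain carbon, seven bonds along the chain from an amide-type nitrogen. Among the measured compounds shown here, no measured step covers this change directly. The nearest analogy is the lengthening of the ester chain from compound 1 to compound 2, which gave no change at the digits printed from compound 1 to compound 2 (within the scatter); the two steps that did move the number, from compound 1 to compound 3 and from compound 2 to compound 3, replaced the whole ester side with an amide rather than lengthening a chain, so they do not speak to a further extension. On that basis the expected step for compound 4 is a 1.1-fold lower number from compound 3 to compound 4 (0.05 log units; within the scatter), within the scatter in either direction. Compound 4 is therefore estimated at 60 nM in this assay, with a range from 20 nM to 200 nM.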

Compound 4, inhibition constant: 600 nM
For compound 4 the middle estimate is 10-fold (1.00 log units) below the measured one, outside the stated range (above it).
By their numbers in this assay, from the lowest: compound 3; then compounds 1, 2 and 4 (each within the scatter of the next).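

In this assay, the amide chain proved sensitive to length: propyl in place of hydrogen, seven bonds along the chain from an amide-type nitrogen, gave a 9.0-fold higher number from compound 3 to compound 4 (0.95 log units; beyond the scatter), while the only earlier chain extension, on the ester side, gave no change at the digits printed from compound 1 to compound 2 (within the scatter). The amide alone therefore does not secure the low number of compound 3, since the decylamino compound stands level with both esters, with decylamino in place of butoxy giving a 1.5-fold higher number from compound 2 to compound 4 (0.18 log units; within the scatter) and decylamino in place of ethoxy giving a 1.5-fold higher number from compound 1 to compound 4 (0.18 log units; within the scatter). The data shown offer no explanation for this reversal.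

As far as these compounds go, what remains open is how the number runs along the octylamino and nonylamino chains, and whether it changes gradually or abruptly between the heptylamino and decylamino ends of the series. Also open, from the compounds shown here alone, are whether shorter amide chains, such as ethylamino or butylamino, match the esters of the same length, and whether a carboxylic acid or an amine at the end of the decyl chain would alter the result.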